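Sulfonyl aryl exchange in the benzylamide series

This account rests on a few compounds, and the source may have more. Where it says the series, first, only, none or still open, it means among the compounds named here.

Two compounds of the shared core have numbers in an assay on MDA-MB-231 cells for displacement of a labelled ligand from C-X-C chemokine receptor type 4 (Homo sapiens), read by fluorescence and microscopy, with stated times of 10 min and 30 min; a higher number here means that more compound is needed for the effect, a lower number that less compound is needed. Compound 1 `O=C(NCc1ccc(CNS(=O)(=O)c2ccccc2Cl)cc1)c1cccnc1` gives 100 nM in this assay, the higher of the two numbers. Compound 2 `Cc1ccccc1C(=O)NCc1ccc(CNS(=O)(=O)c2ccc(Cl)cc2)cc1` gives 1 nM in this assay, but it differs from compound 1 in more than one place, so no single change can be read from that pair.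

Compound 3 `O=C(NCc1ccc(CNS(=O)(=O)c2ccc([N+](=O)[O-])cc2)cc1)c1cccnc1` is not yet measured. It differs from compound 1 in one place: 4-nitrophenyl in place of 2-chlorophenyl on a sulfonyl sulfur. Within the data shown here, no measured pair isolates this change, so the expectation rests on compound 1 alone, with compound 2 showing only that the core can carry a much lower number in this assay. A moderate step downward from compound 1 to compound 3 is expected, a 2.5-fold lower number from compound 1 to compound 3 (0.40 log units; beyond the scatter), though the pair may also stay within the scatter. Compound 3 is therefore estimated at 40 nM in this assay, within a range from 8 nM to 200 nM.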

Compound 3, effective concentration (reported as EC, without a stated level of effect): 100 nM
Compound 3: the middle estimate sits 2.5-fold (0.40 log units) below what was measured; the range from low to high includes it.
By their numbers in this assay, from the lowest: compound 2; then compounds 1 and 3 (each within the scatter of the next).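

In this assay, among these compounds, the exchange of 2-chlorophenyl for 4-nitrophenyl on a sulfonyl sulfur gives no change at the digits printed from compound 1 to compound 3 (within the scatter), the first single change that can be read. At this position of the shared core, with the pyridine-free description set aside, only the aryl group differs, and the two aryl groups cannot be told apart by this read-out. The step changes both the substituent and its printed position together, so neither contribution can be separated, and no measurement on hand offers an explanation for the result.

Still open, as far as these compounds go, is whether a non-aryl group on the sulfonyl sulfur, such as a methyl or a longer alkyl chain, or a phenyl carrying an amine or a carboxylic acid, would shift the number in this assay. Also open is which of the places separating compound 2 from compound 1 accounts for the difference in their numbers.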